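The source may report more compounds than this note shows. Statements on the series, on what has been measured and on what is new or still open speak of the compounds shown alone.

Measured so far in a functional assay on RAW264.7 cells (Mus musculus) for inhibition, read by Griess assay, with stated times of 1 h and 24 h; on this read-out higher numbers stand for weaker inhibition and lower numbers for stronger inhibition:
- Compound 1 `COCCCOc1ccc(C(O)C2OC(=O)c3c(OC)cc(OC)cc32)cc1`: 1260 nM
- Compound 2 `COc1cc(OC)c2c(c1)C(C(O)c1ccc(OCCOc3ccccc3)cc1)OC2=O`: > 10000 nM (a limit of the assay, not a number)

Compound 2 has no number of its own. Its reading of > 10000 nM is only a limit, and it stands at the limit of > 10000 nM in this assay, at which 1 of the 2 values shown sits. Going by the values given here, compound 1 is the only compound here with a true number. Among the compounds with values here, the one measured step, an at least 7.9-fold higher number from compound 1 to compound 2 (0.89 log units; beyond the scatter), replaces methoxymethyl with phenoxy on the same side chain, and its true size is unknown.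

Compound 3 `COc1cc(OC)c2c(c1)C(C(O)c1ccc(OCc3ccc(OC(F)(F)F)cc3)cc1)OC2=O` changes that chain again: 4-(trifluoromethoxy)phenyl in place of phenoxymethyl on a saturated chain carbon bound to an oxygen on an aromatic ring. Here 4-(trifluoromethoxy)phenyl takes the place of phenoxymethyl, so the chain still ends in one six-membered aromatic ring of carbon only. Within the data shown here, the only guide is compound 2, whose step an at least 7.9-fold higher number from compound 1 to compound 2 (0.89 log units; beyond the scatter) came with such a ring, so a return to the level of compound 1 is not expected in this assay. The expected change is small and towards lower numbers, estimated as an at least 1.4-fold lower number from compound 2 to compound 3 (0.15 log units; that floor lies within the scatter). Compound 3 is expected at 7000 nM, with an estimated range from 1500 nM to 30000 nM.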

Compound 3, half-maximal inhibitory concentration: 8140 nM
Compound 3: middle estimate off by 1.2-fold (0.07 log units), on the low side; low and high end bracket the measured number.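

In this assay, going by these compounds alone, compound 3 turns a chain ending in a six-membered aromatic ring of carbon only into a true number for the first time, where the earlier ring-bearing chain had given only a limit. The change of 2-methoxyethyl to 4-(trifluoromethoxy)phenyl on a saturated chain carbon bound to an oxygen on an aromatic ring now gives a measured gap, a 6.5-fold higher number from compound 1 to compound 3 (0.81 log units; beyond the scatter), so the loss that went with the ring no longer rests on a limit alone. The other step, an at least 1.2-fold lower number from compound 2 to compound 3 (0.08 log units; that floor lies within the scatter), has only a floor that lies within the scatter, and compound 2 holds a limit of the assay and not a number, so the true difference between phenoxymethyl and 4-(trifluoromethoxy)phenyl here stays unknown: the limit of > 10000 nM in this assay, at which 1 of the 3 values shown sits.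

As far as these compounds go, whether the higher numbers go with the aromatic ring itself or with the length of the chain stays open, as compound 1 is the only one of the three without such a ring. How an amine, a carboxylic acid or a longer chain ending in methoxy would read at this position is also left open.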